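The source may report more compounds than this note shows. Statements on the series, on what has been measured and on what is new or still open speak of the compounds shown alone.

Measured compounds in the series:

compound 1 `O=C(Nc1cc(C(F)(F)F)cc(C(F)(F)F)c1)c1ccccc1O`: > 10000 nM
compound 2 `O=C(Nc1cc(C(F)(F)F)cc(C(F)(F)F)c1)c1cccc(Cl)c1O`: > 10000 nM
compound 3 `O=C(Nc1cc(Cl)cc(Cl)c1)c1cc(Cl)ccc1O`: > 10000 nM

In an assay on cells for antagonist activity at P2X purinoceptor 2 (Homo sapiens), read by fluorescence and calcium flux, with a stated time of 30 min (on this read-out higher numbers stand for weaker inhibition and lower numbers for stronger inhibition), compound 1 gives > 10000 nM, which is a limit of the assay and not a number. Compound 2 gives > 10000 nM in this assay, again a limit. Compound 3 gives > 10000 nM in this assay, also a limit. For the measured compounds named here, all three values sit at the limit of > 10000 nM in this assay, at which 3 of the 3 values shown sit, so no compound can be ordered against another.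

The change from compound 2 to compound 1 is hydrogen in place of chloro on an aromatic carbon. The step it made, a step that the two limits leave unreadable from compound 2 to compound 1, cannot be read because both ends are limits.

Compound 3 and compound 2 share no single counted difference; the difference between the two cores is not broken down here.

The next compound, compound 4 `O=C(Nc1cccc(Cl)c1)c1cc(Cl)ccc1O`, is not yet measured in this assay. It differs from compound 3 by hydrogen in place of chloro on an aromatic carbon. This is the same kind of change as that from compound 2 to compound 1, but not the same: in compound 2 the chloro leaves a place "ortho to a hydroxy group", whereas in compound 3 it leaves a place "meta to a chloro group"; both places are "meta to a large group".

Going by the values given here, the step from compound 3 to compound 4 is expected to be a step that the limit leaves unreadable from compound 3 to compound 4, on the reasoning that the only comparable change, from compound 2 to compound 1, moved between two limits and gave no sign of a readable gain. Compound 4 is therefore estimated at 20000 nM in this assay, between 8000 nM and 60000 nM, most likely reported as a limit once more.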

Compound 4, half-maximal inhibitory concentration: > 10000 nM
Compound 4 gave a limit, no number; the forecaster's own chance of this, stated with the estimate: 85%; the middle value lies beyond the limit too.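

For the compounds shown here, compound 4 gives > 10000 nM in this assay, which is a limit of the assay and not a number, so the step between compound 3 and compound 4 cannot be read and no new step follows. The series still rests on a single limit: the limit of > 10000 nM in this assay, at which 4 of the 4 values shown sit.

The compounds shown leave open which structural change, if any, would give a readable value in this assay.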